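Aryl ester variation on a shared lactone core

The source may report more compounds than this note shows. Statements on the series, on what has been measured and on what is new or still open speak of the compounds shown alone.

Measured compounds in a functional assay on MCF7 cells (Homo sapiens) for antiproliferative activity, read by MTT assay, with a stated time of 6 days; a lower number here means a stronger inhibitor, a higher number a weaker inhibitor:
compound 1 `CC(=O)O[C@@H]1C=CC(=O)O[C@@H]1[C@@H](COC(=O)c1ccc(Cl)cc1)OC(C)=O`: 2640 nM
compound 2 `CC(=O)O[C@@H]1C=CC(=O)O[C@@H]1[C@@H](COC(=O)c1ccc([N+](=O)[O-])cc1)OC(C)=O`: 5320 nM
compound 3 `O=C1C=C[C@@H](OCc2ccccc2)[C@@H]([C@@H](COC(=O)/C=C/c2ccccc2)OCc2ccccc2)O1`: 2570 nM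

Compound 3 carries the lowest of the three numbers; its gap to compound 1 is within the scatter, its gap to compound 2 beyond it. Compound 4 `COc1ccc(/C=C/C(=O)OC[C@@H](OCc2ccccc2)[C@H]2OC(=O)C=C[C@H]2OCc2ccccc2)cc1` is not yet measured. It differs from compound 3 by methoxy in place of hydrogen on an aromatic carbon. For the measured compounds named here, the only measured step, a 2.0-fold higher number from compound 1 to compound 2 (0.30 log units; within the scatter), also swaps a substituent on an aromatic carbon, and it stayed within the scatter; no step with methoxy itself is on record. Therefore no change beyond the scatter is expected in this assay. The estimated step of a 1.0-fold higher number from compound 3 to compound 4 (0.01 log units; within the scatter) is thus about flat. For compound 4 the expected value is 2600 nM, within 1100 nM to 6200 nM.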

Compound 4, half-maximal inhibitory concentration: 1110 nM
Estimate against measurement, compound 4: 2.3-fold (0.37 log units) above; the range from low to high includes it.
By their numbers in this assay, from the lowest: compound 4; then compounds 3, 1 and 2 (each within the scatter of the next, the first and the last beyond it).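

In this assay, methoxy in place of hydrogen on the aromatic carbon para to a large group gives a 2.3-fold lower number from compound 3 to compound 4 (0.36 log units; beyond the scatter) and is the only step shown that lies beyond the scatter, so this position on the 2-phenylethenyl group responds to substitution. The earlier aromatic swap, a 2.0-fold higher number from compound 1 to compound 2 (0.30 log units; within the scatter), did not show this. No data at hand bear on the origin of the step.

The compounds shown leave open whether an amine or a longer alkoxy chain on that carbon would give a similar step, and whether methoxy would do so on the aromatic ester of compound 1.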